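Sulfur gives way to oxygen in compound 3

The source may report more compounds than this note shows. Statements on the series, on what has been measured and on what is new or still open speak of the compounds shown alone.

Measured so far in a functional assay on MCF7 cells (Homo sapiens) for cytotoxicity, read by CellTiter-Glo, with a stated time of 5 days; on this read-out higher numbers stand for weaker inhibition and lower numbers for stronger inhibition
- compound 1 `CC/C(=C(/c1ccc(/C=C/C(=O)O)cc1)c1ccc(O)nc1)c1ccccc1` gives "not determined" (no result reported)
- compound 2 `CC/C(=C(/c1ccc(/C=C/C(=O)O)cc1)c1ccc2[nH]c(=O)sc2c1)c1ccccc1` gives 158 nM

For the measured compounds named here, compound 2 holds the only number so far, and compound 1 has no result to compare with it. Compound 3 `CC/C(=C(/c1ccc(/C=C/C(=O)O)cc1)c1ccc2[nH]c(=O)oc2c1)c1ccccc1` differs from compound 2 in one place. The change reads a group of 10 heavy atoms (7 carbon, 1 nitrogen, 2 oxygen; one five-membered aromatic ring with 2 hetero atoms, one six-membered aromatic ring of carbon only) in place of a group of 10 heavy atoms (7 carbon, 1 nitrogen, 1 oxygen, 1 sulfur; one five-membered aromatic ring with 2 hetero atoms, one six-membered aromatic ring of carbon only), on a double-bonded chain carbon bound to an aromatic carbon and a double-bonded chain carbon and it puts an oxygen where compound 2 has a sulfur. Going by the values given here, no measured step shows what such a swap does. The estimated change is a 1.1-fold higher number from compound 2 to compound 3 (0.06 log units; within the scatter) in this assay and is expected to stay within the usual scatter, with no clear direction. Among the compounds with values here, the sole anchor is compound 2 at 158 nM and that leaves the range wide. Compound 3 is expected at 180 nM with an estimated range from 55 nM to 600 nM in this assay.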

Compound 3, half-maximal inhibitory concentration: 56 nM
For compound 3 the middle estimate is 3.2-fold (0.51 log units) above the measured one; the range from low to high includes it.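

In this assay, putting an oxygen where compound 2 has a sulfur, with the hydrogen-bond donor and acceptor counts of the group unchanged, gives a 2.8-fold lower number from compound 2 to compound 3 (0.45 log units; beyond the scatter). This shows that a single atom in this group, on a double-bonded chain carbon, can shift the read-out, and that oxygen gives the lower number of the two atoms tried. Nothing available explains the shift.

On these data alone, whether a nitrogen or a carbon in place of that oxygen would lower the number further stays open. Compound 1 has no result, so it offers no comparison.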